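The compounds below may be only part of what the source reports. "The series", "measured", "known", "first", "only" and "open" are said of these compounds alone.

Measured compounds:
- compound 1 `ClCc1ccccc1Cn1cnc2c(Cl)nc(Cl)nc21`: 130 nM
- compound 2 `ClCc1ccccc1Cn1cnc2c(Cl)ncnc21`: 5620 nM
- compound 3 `ClCc1cccc(Cn2cnc3c(Cl)nc(Cl)nc32)c1`: 1580 nM

In a functional assay on DU-145 cells (Homo sapiens) for cytotoxicity, read by sulforhodamine B assay, with a stated time of 48 h (on this read-out lower numbers stand for stronger inhibition of growth and higher numbers for weaker inhibition of growth), compound 2 stands with the highest number of the three. Its nearest neighbour is compound 3, which gives 1580 nM; the furthest is compound 1, which gives 130 nM. Going by the values given here, the one step that has been measured at the position now in question is the loss of chloro from compound 1 to compound 2, and it is large: a 43-fold higher number from compound 1 to compound 2 (1.64 log units; beyond the scatter).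

The next compound to be tested is compound 4 `Nc1nc(Cl)c2ncn(Cc3ccccc3CCl)c2n1`. It differs from compound 2 by amino in place of hydrogen on an aromatic carbon. So the change restores a group at the very position whose emptying produced the large step from compound 1 to compound 2. Among the compounds with values here, that step bears on the present one in so far as it shows this position to be sensitive, but no amino-bearing analogue has been measured, and nothing here tells whether amino behaves as chloro does. He therefore expects a gain that is beyond the scatter but smaller than the step seen from compound 1 to compound 2, with wide uncertainty. For compound 4 the expected step is a 2.8-fold lower number from compound 2 to compound 4 (0.45 log units; beyond the scatter). His estimate for compound 4 in this assay is 2000 nM, within a range of 300 nM to 12000 nM.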

Compound 4, concentration for 50% growth inhibition: 14800 nM
Compound 4: middle estimate off by 7.4-fold (0.87 log units), on the low side; the measured number lies above the stated range.
By their numbers in this assay, from the lowest: compound 1; then compound 3; then compound 2; then compound 4.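

In this assay, the position between two ring nitrogen atoms does not simply reward having a group on it: amino fails to recover what the loss of chloro gave up, and a 2.6-fold higher number from compound 2 to compound 4 (0.42 log units; beyond the scatter) moves the number further from that of compound 1, not back towards it. Set directly against chloro, the change is large, with a 110-fold higher number from compound 1 to compound 4 (2.06 log units; beyond the scatter) as the printed step, so the order at this position runs from chloro through hydrogen to amino. The earlier compounds showed only that the position was sensitive, whereas this result shows that a group here can give a weaker result than hydrogen, and nothing available explains this order of chloro, hydrogen and amino.

The compounds shown leave open whether this loss belongs to amino alone or to groups other than chloro in general, a question that bromo, methoxy or methylamino at the same position could help to settle. They also leave open whether amino in place of chloro would give a similar step from compound 3, which gives 1580 nM in this series.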